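One More Methyl on Compound 3

A few compounds are considered here, and "the series" means these few. Any claim that something is new, unique, unknown or untested is made for them only; others in the source may bear on it.

Measured in a physicochemical assay for solubility, at pH 6.8; a higher number here means a more soluble compound, a lower number a less soluble compound:
- Compound 1 `COC(=O)c1nc(-c2ccco2)c(C(F)(F)F)cc1N`: 11 ug/mL
- Compound 2 `CCc1nc(C(=O)NCC(C)(O)C(F)(F)F)c(N)cc1C(F)(F)F`: 91 ug/mL
- Compound 3 `CNc1nc(C(=O)NCC(C)(O)C(F)(F)F)c(N)cc1C(F)(F)F`: 13 ug/mL

Of these three numbers, compound 3 holds the second highest place at 13 ug/mL, although it lies within the scatter of compound 1. Only compound 2 stands clearly apart from it.

The next compound is compound 4 `CN(C)c1nc(C(=O)NCC(C)(O)C(F)(F)F)c(N)cc1C(F)(F)F`, which turns methylamino into dimethylamino: methyl in place of hydrogen on a nitrogen on an aromatic ring. In words, a methyl takes the place of a hydrogen on a nitrogen on an aromatic ring.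

Compound 1 differs from the others in more than one place, so it offers no clean comparison. Within the data shown here, one measured step bears on the change, a modest one that arose when methylamino took the place of ethyl: a 7.0-fold lower number from compound 2 to compound 3 (0.85 log units; beyond the scatter). It shows that this assay can respond to a change at this group. However, it replaces one whole group with another, while compound 4 only gains a methyl. Among the measured compounds shown here, no measured pair shows that exact change, so the evidence is thin. From the compounds shown here alone, no step beyond the scatter is expected, and the direction remains open.

The estimated step is a 1.2-fold higher number from compound 3 to compound 4 (0.09 log units; within the scatter).

Compound 4 is expected at 16 ug/mL, with an estimated range from 6 ug/mL to 50 ug/mL.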

Compound 4, solubility: 165 ug/mL
Beside the measured number, compound 4's estimate is 10-fold (1.01 log units) below it; the whole stated range lies below it.
By their numbers in this assay, from the lowest: compounds 1 and 3 (each within the scatter of the next); then compounds 2 and 4 (each within the scatter of the next).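

In this assay, a single added methyl on this nitrogen has a large effect: the change gives a 13-fold higher number from compound 3 to compound 4 (1.10 log units; beyond the scatter) and takes methylamino to dimethylamino with only one carbon gained. The earlier drop from ethyl to methylamino therefore cannot be read as a general penalty for attaching a nitrogen at this place on the aromatic ring, as dimethylamino is also attached through nitrogen and the comparison with ethyl gives a 1.8-fold higher number from compound 2 to compound 4 (0.26 log units; within the scatter) within the scatter. What separates compound 3 from compound 4 is the hydrogen on that nitrogen being replaced by a methyl, but no measurement shown here explains why this shifts the number so strongly.

From the compounds shown here alone, three groups at this place on one shared core give only a narrow view, so it remains open whether a longer chain on the nitrogen, such as diethylamino, or a ring amine, such as morpholine, would stay level with compound 4 or fall away. The unsubstituted amine at this place would also show whether the number follows a steady trend as methyls are added, or whether compound 3 is an isolated low point.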